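Cyclohexyl in place of pyridinylmethyl on the amide

A few compounds are considered here, and "the series" means these few. Any claim that something is new, unique, unknown or untested is made for them only; others in the source may bear on it.

Compound 2 `O=C(Cc1ccccn1)N[C@H]1CCC[C@H](NC(=O)c2cccc(Cl)c2)C1` carries a (pyridin-2-yl)methyl group on one of its two amide carbonyl carbons. In a functional assay on HEK293 cells for antagonist activity at metabotropic glutamate receptor 5 (Homo sapiens), read by FLIPR and calcium flux (a higher number here means a weaker inhibitor, a lower number a stronger inhibitor), compound 2 reaches only the limit of > 10000 nM, so no exact number is known for it. Compound 1 `CN(C)c1ccc(C(=O)N[C@H]2CCC[C@H](NC(=O)c3cccc(Cl)c3)C2)cc1` has 4-(dimethylamino)phenyl at that carbonyl and gives 473 nM in this assay. The step of an at least 21-fold higher number from compound 1 to compound 2 (1.32 log units; beyond the scatter) shows a large loss of inhibition. One of the two values sits at the limit of > 10000 nM in this assay, at which 1 of the 2 values shown sits. Compound 3 `O=C(N[C@H]1CCC[C@H](NC(=O)C2CCCCC2)C1)c1cccc(Cl)c1` has not been measured; it differs from compound 2 by cyclohexyl in place of (pyridin-2-yl)methyl on a carbonyl carbon. Among the measured compounds shown here, no measured step involves cyclohexyl, and the only known step, an at least 21-fold higher number from compound 1 to compound 2 (1.32 log units; beyond the scatter), moved away from an aromatic group toward weaker inhibition, so compound 3 is expected to stay weak, with the step of a number no higher from compound 2 to compound 3 (the limit leaves the size open) expected to lie within the scatter. Compound 3 is estimated at 10000 nM, in a range from 3000 nM to 30000 nM.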

Compound 3, half-maximal inhibitory concentration: 857 nM
Beside the measured number, compound 3's estimate is 12-fold (1.07 log units) above it; the measured number lies below the stated range.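

Changing only the group on this carbonyl carbon restores inhibition, with an at least 11-fold lower number from compound 2 to compound 3 (1.06 log units; beyond the scatter). That size is a lower bound, since compound 2 has a limit of the assay and not an exact number: the limit of > 10000 nM in this assay, at which 1 of the 3 values shown sits. With a 1.8-fold higher number from compound 1 to compound 3 (0.26 log units; within the scatter), cyclohexyl and 4-(dimethylamino)phenyl cannot be told apart in this assay, so among these compounds an aromatic ring at this place is not required for inhibition, and a ring of carbon only serves as well.

The compounds shown leave open whether the weakness of compound 2 comes from the nitrogen in its pyridine ring or from the extra carbon linking that ring to the carbonyl. A benzyl group or a cyclohexylmethyl group on this carbonyl carbon would separate these two possibilities.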